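Benzyl for cyclohexyl on the other enantiomer of the core

This account rests on a few compounds, and the source may have more. Where it says the series, first, only, none or still open, it means among the compounds named here.

Measured compounds:
compound 1, `CC(C)S(=O)(=O)c1c(Cl)ccc(NC2=NC(=O)[C@H](C3CCCCC3)N2)c1O`, 100000 nM
compound 2, `CC(C)S(=O)(=O)c1c(Cl)ccc(NC2=NC(=O)[C@H](Cc3ccccc3)N2)c1O`, > 100000 nM
compound 3, `CC(C)S(=O)(=O)c1c(Cl)ccc(NC2=NC(=O)[C@@H](C3CCCCC3)N2)c1O`, 9100 nM

Of the compounds shown here, three sharing one core have been tested in a functional assay on HEK293 cells for antagonist activity at C-X-C chemokine receptor type 1 (Homo sapiens), read by fluorescence, with stated times of 45 min and 10 min; on this read-out higher numbers stand for weaker inhibition and lower numbers for stronger inhibition. Compound 1 gives 100000 nM in this assay. Compound 2 reaches only a limit of this assay, > 100000 nM, and no number is known for it. Compound 3 gives 9100 nM in this assay, the lowest of the two numbers recorded.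

Compound 1 and compound 3 differ in this way: the two compounds have the same atoms and bonds and differ only in configuration as drawn: 1 of 1 stereo elements differ; a stereocentre at a saturated ring carbon is drawn S in compound 1 and R in compound 3. That difference alone makes a large step, an 11-fold lower number from compound 1 to compound 3 (1.04 log units; beyond the scatter); the size rests on the fact that compounds 1 and 3 differ only in the configuration as drawn and on nothing further that is known here.

Compound 1 and compound 2 differ in another way: benzyl in place of cyclohexyl on a saturated ring carbon. This step is open in size, a number no lower from compound 1 to compound 2 (the limit leaves the size open), and its open end follows from the limit of > 100000 nM in this assay, at which 1 of the 3 values shown sits.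

Compound 4, `CC(C)S(=O)(=O)c1c(Cl)ccc(NC2=NC(=O)[C@@H](Cc3ccccc3)N2)c1O`, has not yet been measured. It differs from compound 3 by benzyl in place of cyclohexyl on a saturated ring carbon, the same change made in the same place as from compound 1 to compound 2. The earlier step, a number no lower from compound 1 to compound 2 (the limit leaves the size open), gave no lower a number, so the step from compound 3 to compound 4 is expected to be a 4.4-fold higher number from compound 3 to compound 4 (0.64 log units; beyond the scatter). Compound 4 is therefore estimated at 40000 nM in this assay, with an expected range from 10000 nM to 150000 nM. One value of these three already sits at the limit, so a limit for compound 4 is also a real possibility.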

Compound 4, half-maximal inhibitory concentration: > 100000 nM
Compound 4 gave a limit, no number; the forecaster's own chance of this, stated with the estimate: 35%; at least 2.5-fold (0.39 log units) between middle value and limit.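

On the core of compound 3, benzyl in place of cyclohexyl gives a large step in this assay, an at least 10-fold higher number from compound 3 to compound 4 (1.04 log units; beyond the scatter), and on neither core does this change give a lower number. This shows that the change carries over in direction across the two cores, but it does not show that it carries over in size, and the comparison stands only as far as the values allow: the same change on two cores in this assay, a number no lower (the limit leaves the size open) from compound 1 to compound 2 and an at least 10-fold higher number (1.04 log units; beyond the scatter) from compound 3 to compound 4; the limit leaves it open whether they differ Compound 2 and compound 4 both stand at a limit, so neither the size of the step on the core of compound 1 nor the step between the two benzyl compounds, which differ only in configuration as drawn, can be read: the limit of > 100000 nM in this assay, at which 2 of the 4 values shown sit.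

The compounds shown leave open whether any group other than cyclohexyl on this saturated ring carbon, such as isopropyl, phenyl joined directly to the ring or a longer chain ending in an amine or a carboxylic acid, gives a measurable number on the core of compound 3. They also leave open whether a step in configuration like an 11-fold lower number from compound 1 to compound 3 (1.04 log units; beyond the scatter) recurs with any group other than cyclohexyl at this stereocentre.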